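A few compounds are considered here, and "the series" means these few. Any claim that something is new, unique, unknown or untested is made for them only; others in the source may bear on it.

In an ADME assay on MT4 cells (Homo sapiens) for cytotoxicity, read by MTT assay (a higher number here means that more compound is tolerated, a lower number that less compound is tolerated), compound 3 (`O=C1c2ccccc2C(=O)N1CCOC(=S)N(C(=O)c1ccco1)c1ccc(Cl)cc1Cl`) gives > 100000 nM as its reading, which is a limit of the assay and not a number. It stands at the limit of > 100000 nM in this assay, at which 1 of the 3 values shown sits, and so offers no exact starting point. Compound 1 (`O=C1c2ccccc2C(=O)N1CCOC(=S)N(C(=O)c1ccc(Cl)c(Cl)c1)c1ccc(Cl)cc1`) gives 35000 nM as a measured number, and compound 2 (`Cc1cc(C(=O)N(C(=S)OCCN2C(=O)c3ccccc3C2=O)c2ccc(Cl)cc2)c(C)o1`) gives 40000 nM as a measured number. Compound 4 (`O=C1c2ccccc2C(=O)N1CCOC(=S)N(C(=O)c1ccco1)c1cc(Cl)cc(Cl)c1`) has yet to be measured, and it departs from compound 3 as follows: 3,5-dichlorophenyl in place of 2,4-dichlorophenyl on an amide-type nitrogen with 3,5-dichlorophenyl in place of 2,4-dichlorophenyl on an amide-type nitrogen. Within the data shown here, no measured step changes the group on that nitrogen. Among the measured compounds shown here, the only measured step (a 1.1-fold higher number from compound 1 to compound 2 (0.06 log units; within the scatter)) sits on a carbonyl carbon, so it bears on the question only indirectly, and its small size gives no reason to expect a large move. Compound 1 and compound 2 both gave numbers, so a modest downward move is the working expectation, though compound 4 may also reach the limit. The expected change is an at least 1.4-fold lower number from compound 3 to compound 4 (0.15 log units; that floor lies within the scatter) as an estimate. For compound 4 the estimated value is 70000 nM with an expected range from 30000 nM to 100000 nM in this assay once it is measured.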

Compound 4, half-maximal cytotoxic concentration: > 100000 nM
Compound 4: a limit, no number; the forecaster's own chance of this, stated with the estimate: 45%; middle value at least 1.4-fold (0.15 log units) from the limit.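

In this assay, compound 3 and compound 4 both end at a limit of the assay and not at a number, so no step between the two can be read: the limit of > 100000 nM in this assay, at which 2 of the 4 values shown sit.

The compounds shown leave open whether 3,5-dichlorophenyl and 2,4-dichlorophenyl on the amide-type nitrogen differ at all in this assay, and in which direction.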